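A few compounds are considered here, and "the series" means these few. Any claim that something is new, unique, unknown or untested is made for them only; others in the source may bear on it.

Measured so far in a functional assay on SF-268 cells (Homo sapiens) for inhibition, read by sulforhodamine B assay, with a stated time of 48 h; a higher number here means a weaker inhibitor of growth, a lower number a stronger inhibitor of growth:
Compound 1 `O=C(Nc1cccc(-n2cc(-c3ccncc3)c(-c3ccc(Cl)c(O)c3)n2)c1)Nc1cccc(C(F)(F)F)c1` gives 15800 nM.
Compound 2 `COc1cc(-c2nn(-c3cccc(NC(=O)Nc4ccc(Cl)c(Cl)c4)c3)cc2-c2ccncc2)ccc1Cl` gives 20300 nM.
Compound 3 `O=C(Nc1cccc(-n2cc(-c3ccncc3)c(-c3ccc(Cl)c(O)c3)n2)c1)Nc1ccc(Cl)c(Cl)c1` gives 10900 nM.

Compound 1 stands second highest of the three numbers; its nearest neighbour is compound 2 and its furthest is compound 3, and both gaps lie within the scatter, so the three compounds cannot be separated in this assay. Two single-point steps are known: a 1.4-fold lower number from compound 1 to compound 3 (0.16 log units; within the scatter), and a 1.9-fold lower number from compound 2 to compound 3 (0.27 log units; within the scatter). Neither moves the number beyond the scatter.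

Compound 4 `O=C(Nc1cccc(-n2cc(-c3ccncc3)c(-c3ccc(Cl)c(O)c3)n2)c1)Nc1cc(C(F)(F)F)cc(C(F)(F)F)c1` is reached from compound 1 by trifluoromethyl in place of hydrogen on an aromatic carbon. The entering group sits on the six-membered aromatic ring of carbon only that already carries a trifluoromethyl group, meta to it. Of the known steps, a 1.4-fold lower number from compound 1 to compound 3 (0.16 log units; within the scatter) bears on this change, as it too reworks the substituents of that ring, and it stayed within the scatter. The step from compound 2 to compound 3 concerns the other end of the shared core and says nothing about this ring. A second substituent on the same ring is therefore expected to leave this assay essentially unchanged, with no step beyond the scatter in either direction. Compound 4 is expected to give 14000 nM, with a range from 6000 nM to 35000 nM. For compound 4 this amounts to an expected step of a 1.1-fold lower number from compound 1 to compound 4 (0.05 log units; within the scatter).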

Compound 4, concentration for total growth inhibition: 2690 nM
Compound 4: the middle estimate sits 5.2-fold (0.72 log units) above what was measured, outside the stated range (below it).
By their numbers in this assay, from the lowest: compound 4; then compounds 3, 1 and 2 (each within the scatter of the next).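

In this assay, among these compounds, trifluoromethyl in place of hydrogen on an aromatic carbon, meta to a trifluoromethyl group, gives a 5.9-fold lower number from compound 1 to compound 4 (0.77 log units; beyond the scatter), the first step that lies beyond the scatter. The earlier rework of this ring, a 1.4-fold lower number from compound 1 to compound 3 (0.16 log units; within the scatter), stayed within the scatter, so this aromatic carbon is the first place shown where a single change separates two compounds. Nothing measured accounts for the size of this step.

From the compounds shown here alone, it stays open whether a nitrile, an amine or a carboxylic acid on the same aromatic carbon would move the number as trifluoromethyl does, since a single step at this place sets no trend. Also open, going by these compounds, is whether the step holds when methyl sits on the oxygen, as in compound 2.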